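This account rests on a few compounds, and the source may have more. Where it says the series, first, only, none or still open, it means among the compounds named here.

Measured so far:
- compound 1, `O=C(Nc1cc2nc(C3CCCCC3)[nH]c2cc1N1CCCC1)OCC(F)(F)F`: in an ADME assay on Vero cells (Chlorocebus sabaeus) for cytotoxicity, read by resazurin assay, with a stated time of 3 days (on this read-out higher numbers stand for weaker inhibition and lower numbers for stronger inhibition), compound 1 gives > 100 ug/mL
- compound 2, `CCN(CC)c1cc2[nH]c(C3CCCCC3)nc2cc1NC(=O)OCC(F)(F)F`: in this assay compound 2 gives > 100 ug/mL

The value of compound 1 is a limit of the assay, not a number. The value of compound 2 is likewise a limit, and compound 2 therefore stands at the limit of > 100 ug/mL in this assay, at which 2 of the 2 values shown sit, with no number of its own to place it more closely. Within the data shown here, the only step between measured compounds, a step that the two limits leave unreadable from compound 1 to compound 2, cannot be sized because both ends are limits.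

Compound 3, `CCCNC(=O)Nc1cc2nc(C3CCCCC3)[nH]c2cc1N(CC)CC`, differs from compound 2 by propylamino in place of 2,2,2-trifluoroethoxy on a carbonyl carbon. No measured step touches this change; the one step shown is unreadable. On that thin ground the step that the limit leaves unreadable from compound 2 to compound 3 is expected to stay within the scatter, and compound 3 is expected to give a limit again, with an estimate of 150 ug/mL and a range from 50 ug/mL to 400 ug/mL.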

Compound 3, half-maximal inhibitory concentration: > 100 ug/mL
Compound 3 ended at the assay's limit; the forecaster's own chance of this, stated with the estimate: 80%; the middle value does not contradict the limit.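

Among these compounds, compound 2 and compound 3 give no numbers to compare, and no step between them can be read, because each value is a limit of the assay: the limit of > 100 ug/mL in this assay, at which 3 of the 3 values shown sit. Going by these compounds, what remains open is whether the change at the carbonyl carbon alters the result in this assay at all.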